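What Replacing the Nitro Group Might Do

The source may hold more compounds than are shown below. What is called first, only, known or untested is meant among the compounds shown, and "the series" means these compounds.

- compound 1 `CN(C)CCCN(/N=N/c1ccc([N+](=O)[O-])cc1)c1ccccc1` gives 36000 nM
- compound 2 `CN(C)CCCN(/N=N/c1cccc([N+](=O)[O-])c1)c1ccccc1` gives 54000 nM

These numbers come from an ADME assay on BHK-21 cells (Mesocricetus auratus) for cytotoxicity, read by MTT assay, with a stated time of 96 h; on this read-out lower numbers stand for higher toxicity in this test and higher numbers for lower toxicity in this test. There, compound 2 stands at 54000 nM, and this lies within the usual scatter of compound 1 at 36000 nM. On these data, the two compounds cannot be told apart. For the measured compounds named here, both carry a nitro group, and no measured pair shows what happens when that group is lost.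

Compound 3 `CN(C)CCCN(/N=N/c1ccccc1)c1ccccc1` has not yet been measured. It differs from compound 2 in one place, with hydrogen in place of nitro on an aromatic carbon. Going by the values given here, with no measured step to serve as a guide, nothing points in either direction, so no change beyond the scatter is expected in this assay. The expected step is a 1.1-fold lower number from compound 2 to compound 3 (0.03 log units; within the scatter). Compound 3 is expected to give about 50000 nM, with an estimated range from 20000 nM to 120000 nM.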

Compound 3, half-maximal cytotoxic concentration: 50000 nM
Estimate against measurement, compound 3: no gap at the digits printed; low and high end bracket the measured number.
By their numbers in this assay, from the lowest: compounds 1, 3 and 2 (each within the scatter of the next).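

In this assay, the step of a 1.1-fold lower number from compound 2 to compound 3 (0.03 log units; within the scatter) and the step of a 1.4-fold higher number from compound 1 to compound 3 (0.14 log units; within the scatter) both lie within the scatter. The earlier pair compared only two places for the nitro group, whereas these steps show that losing it altogether, from either place, gives no difference that can be told from the usual scatter. Nothing at hand bears on why this is so.

Going by these compounds, what remains open is whether a different group on that aromatic carbon, such as an amine, a carboxylic acid or a methoxy group, would shift the number beyond the scatter. The three compounds also leave open whether a change elsewhere on the shared core, rather than on this ring position, would matter in this cell test.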